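This account rests on a few compounds, and the source may have more. Where it says the series, first, only, none or still open, it means among the compounds named here.

For the measured compounds named here, only two related compounds have so far been tested in a functional assay on HeLa cells (Homo sapiens) for inhibition, read by MTT assay, with a stated time of 48 h; a lower number here means a stronger inhibitor of growth, a higher number a weaker inhibitor of growth. Compound 1 `Cn1cc(C2CC(c3ccccc3)=NN2C(=O)c2cccnc2)c2ccccc21` gives > 10000 nM, which is a limit of the assay and not a number. Going by the values given here, compound 2 `COc1ccc2c(c1)c(C1CC(c3ccc(Cl)cc3)=NN1C(=O)c1ccc(OC)nc1)cn2C` gives 2260 nM, the only actual number available, so it serves as the single reference point for what follows.

Compound 3 `COc1cccc(C2=NN(C(=O)c3ccc(OC)nc3)C(c3cn(C)c4ccc(OC)cc34)C2)c1` has not yet been measured. It carries 3-methoxyphenyl in place of 4-chlorophenyl on a carbon with a double bond to nitrogen, and the change counts as 3-methoxyphenyl in place of 4-chlorophenyl on a carbon with a double bond to nitrogen.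

Among the compounds with values here, no measured pair of compounds differing in one place is available, so the size of this change has no direct precedent. Within the data shown here, the expectation therefore starts from compound 2 at 2260 nM, and no step clearly beyond the usual scatter is anticipated, only a slight drift toward weaker inhibition of growth. The expected change runs a 1.3-fold higher number from compound 2 to compound 3 (0.12 log units; within the scatter), and it remains uncertain in either direction. In this assay the estimate for compound 3 is 3000 nM, with an expected range from 1000 nM to 9000 nM.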

Compound 3, concentration for 50% growth inhibition: 340 nM
Estimate against measurement, compound 3: 8.8-fold (0.95 log units) above, outside the stated range (below it).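

The change of 4-chlorophenyl to 3-methoxyphenyl on a carbon with a double bond to nitrogen gives a 6.6-fold lower number from compound 2 to compound 3 (0.82 log units; beyond the scatter) in this assay, so growth inhibition in these cells responds to the aryl group at this position. The earlier compounds shown here offered no pair differing in one place, which makes this the first measured size of any single change, and it points toward stronger inhibition of growth, modest in size but beyond the usual scatter. The swap alters several things at once: 3-methoxyphenyl has one hydrogen-bond acceptor where 4-chlorophenyl has none, carries oxygen in place of chlorine, and has one more heavy atom, and this single step cannot separate these differences.

On these data alone, whether the methoxy group or the loss of chlorine carries the step stays open, as does how a phenyl ring bearing an amine or a carboxylic acid would fare at this position. Compound 1 remains a limit and not a number, so it adds no measured step to the series: the limit of > 10000 nM in this assay, at which 1 of the 3 values shown sits.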